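Chloro added to compound 2's isatin-side aromatic ring

A few compounds are considered here, and "the series" means these few. Any claim that something is new, unique, unknown or untested is made for them only; others in the source may bear on it.

Measured compounds:
compound 1 `O=C1C(=O)N(CC(CO)NCCCCNc2ccnc3cc(Cl)ccc23)c2ccccc21`: 37%
compound 2 `O=C1C(=O)N(CC(CO)NCCCNc2ccnc3cc(Cl)ccc23)c2ccccc21`: 85%

In an ADME assay on HCT-116 cells (Homo sapiens) for cytotoxicity, read by MTT assay, with a stated time of 48 h, tested at 20 uM (on this read-out higher numbers stand for a stronger effect at the one concentration tested and lower numbers for a weaker effect), compound 2 gives 85%. In the same this assay compound 1 gives 37%. Compound 2 thus stands highest of the two numbers, and its nearest neighbour, compound 1, lies a long way lower, a gap beyond the usual scatter. Compound 3 `O=C1C(=O)N(CC(CO)NCCCNc2ccnc3cc(Cl)ccc23)c2ccc(Cl)cc21` is not yet measured in this assay. It is built from compound 2 by the change (chloro in place of hydrogen on an aromatic carbon), on an aromatic carbon of a six-membered aromatic ring of carbon only, part of a fused system of two rings. No measured pair shows this change, so nothing in the shown numbers says how large its effect is. The expected step from compound 2 to compound 3 is a number 7 percentage points lower from compound 2 to compound 3 (within the scatter), that is, no change beyond the scatter, with a modest downward lean as the more likely direction. Compound 3 is therefore estimated at 78%, within a range from 50% to 95%.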

Compound 3, a percentage reported as inhibition, at one concentration (the size of the read-out at that concentration, not a potency): 46%
For compound 3 the middle estimate is 32 percentage points above the measured one, outside the stated range (below it).
By their numbers in this assay, from the lowest: compounds 1 and 3 (each within the scatter of the next); then compound 2.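

In this assay, chloro in place of hydrogen on this aromatic carbon gives a number 39 percentage points lower from compound 2 to compound 3 (beyond the scatter). For the compounds shown here, this pair is the first to show that this carbon of the six-membered aromatic ring of carbon only is sensitive to substitution: the addition of one chlorine atom moves the read-out beyond the scatter at the one concentration tested. Nothing measured here bears on why the step has this size.

From the compounds shown here alone, whether fluoro, methyl or methoxy on the same aromatic carbon would give a step of similar size remains open, so the result cannot yet be assigned to chloro specifically rather than to any group at this place. Going by these compounds, it is also open whether chloro at this carbon would produce a similar step in compound 1, with its longer chain.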